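The source may report more compounds than this note shows. Statements on the series, on what has been measured and on what is new or still open speak of the compounds shown alone.

Working notes on the series

The read-out throughout is a functional assay on HeLa S3 cells (Homo sapiens) for antiproliferative activity, read by XTT assay, with a stated time of 72 h; a higher number here means a weaker inhibitor, a lower number a stronger inhibitor. Compound 1 `CNc1ncnc2c1c(-c1cc3ccccc3o1)cn2[C@@H]1O[C@H](CO)[C@@H](O)[C@H]1O` carries a 1-benzofuran-2-yl group on its core. In this assay compound 1 reaches only the limit of the assay, > 20000 nM, and no number. Compound 2 `CNc1ncnc2c1c(-c1ccco1)cn2[C@@H]1O[C@H](CO)[C@@H](O)[C@H]1O` differs from compound 1 by furan-2-yl in place of 1-benzofuran-2-yl on an aromatic carbon. In this assay compound 2 gives 5000 nM. The step of an at least 4.0-fold lower number from compound 1 to compound 2 (0.60 log units; beyond the scatter) is therefore the one measured effect of this change so far, and its size is known only as a lower bound, since compound 1 sits at the limit.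

Compound 3 `Nc1nc(N)c2c(-c3cc4ccccc4o3)cn([C@@H]3O[C@H](CO)[C@@H](O)[C@H]3O)c2n1` carries the same 1-benzofuran-2-yl group on a different core; how the core of compound 3 differs from the core of compound 1 is not broken down here. In this assay compound 3 also reaches only the limit of the assay, > 20000 nM. Compound 4 `Nc1nc(N)c2c(-c3ccco3)cn([C@@H]3O[C@H](CO)[C@@H](O)[C@H]3O)c2n1` is not yet measured in this assay and differs from compound 3 by furan-2-yl in place of 1-benzofuran-2-yl on an aromatic carbon, the same change as that from compound 1 to compound 2 at the same place.

Compound 3 stands at the limit of > 20000 nM in this assay, at which 2 of the 3 values shown sit, so the step to compound 4 can be gauged only against that limit and against the earlier step. The expected step is an at least 2.5-fold lower number from compound 3 to compound 4 (0.39 log units; beyond the scatter), estimated on the same footing as the earlier step, with the reservation that a compound starting at the limit may end there too. Compound 4 is accordingly expected to give about 8000 nM in this assay, within 2000 nM to 20000 nM.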

Compound 4, half-maximal inhibitory concentration: > 20000 nM
Compound 4: a limit, no number (the forecaster's own chance of this, stated with the estimate: 35%); at least 2.5-fold (0.39 log units) between middle value and limit.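

Compound 3 and compound 4 both end at a limit rather than a number in this assay, so no step can be read between them: the limit of > 20000 nM in this assay, at which 3 of the 4 values shown sit.

The compounds shown leave open whether furan-2-yl in place of 1-benzofuran-2-yl changes the read-out at all on the core of compound 3, as it does on the core of compound 1.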